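The source may hold more compounds than are shown below. What is called first, only, known or untested is meant among the compounds shown, and "the series" means these compounds.

Series in a functional assay on T47D cells (Homo sapiens) for antiproliferative activity, read by MTT assay, with a stated time of 72 h; on this read-out lower numbers stand for stronger inhibition and higher numbers for weaker inhibition:
- compound 1 `O=C(Nc1ccc(Cl)c(-c2nnc3c(Cl)cccn23)c1)c1ccccn1` gives only a limit, > 100000 nM
- compound 2 `Cc1nc(C(=O)Nc2ccc(Cl)c(-c3nnc4c(Cl)cccn34)c2)cs1` gives only a limit, > 100000 nM
- compound 3 `O=C(Nc1ccc(Cl)c(-c2nnc3c(Cl)cccn23)c1)c1ccc(Cl)cc1` gives only a limit, > 100000 nM

Compound 3 stands nowhere apart from the others: its value in this assay is a limit and not a number, and the two further values shown are limits of the same kind. All three sit together at the limit of > 100000 nM in this assay, at which 3 of the 3 values shown sit. The steps connecting them, a step that the two limits leave unreadable from compound 1 to compound 2, a step that the two limits leave unreadable from compound 1 to compound 3 and a step that the two limits leave unreadable from compound 2 to compound 3, cannot be sized; both ends of each lie at the limit, so none gives a readable size or direction for a change of the group on the carbonyl carbon.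

Compound 4 `O=C(Nc1ccc(Cl)c(-c2nnc3c(Cl)cccn23)c1)c1cccc(Cl)c1` differs from compound 3 only in 3-chlorophenyl in place of 4-chlorophenyl on a carbonyl carbon. The three measured steps bear on this change only in that every variation of the group on the carbonyl carbon so far has left the read-out at the limit. With nothing to suggest that moving the chlorine restores inhibition, the expected step is a number no higher from compound 3 to compound 4 (the limit leaves the size open), that is, no change beyond the scatter and most likely a further limit. Compound 4 is accordingly estimated at 100000 nM, in a range from 30000 nM to 300000 nM, with a high chance that this assay again reports only a limit.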

Compound 4, half-maximal inhibitory concentration: 30200 nM
For compound 4 the middle estimate is 3.3-fold (0.52 log units) above the measured one, within the range that was stated.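

In this assay, the group on the carbonyl carbon does move the read-out: with the same atoms joined differently, 3-chlorophenyl in place of 4-chlorophenyl gives an at least 3.3-fold lower number from compound 3 to compound 4 (0.51 log units; beyond the scatter), so the place of the chlorine on the phenyl ring separates a measured number from a limit. Against the other two groups the picture is the same, with an at least 3.3-fold lower number from compound 2 to compound 4 (0.51 log units; beyond the scatter) and an at least 3.3-fold lower number from compound 1 to compound 4 (0.51 log units; beyond the scatter), and among the four groups shown, 3-chlorophenyl alone gives a number rather than a limit. The steps among compound 1, compound 2 and compound 3 cannot be read, and those three compounds remain together at the limit of the assay: the limit of > 100000 nM in this assay, at which 3 of the 4 values shown sit.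

From the compounds shown here alone, each of the three new steps starts from a limit, and their true sizes stay open. Going by these compounds, it also stays open whether the lower number depends on chlorine itself or on any group at that place on the ring, a question that 3-fluorophenyl, 3-methoxyphenyl or 3-aminophenyl on the same carbonyl carbon would address, while 2-chlorophenyl would complete the set of chlorine placements.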